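This account rests on a few compounds, and the source may have more. Where it says the series, first, only, none or still open, it means among the compounds named here.

Compound 2, `CCN1CCN(c2cc(Nc3cc(C)nn3C(=O)OC(C)(C)C)nc(N[C@H]3CCN(C(=O)c4ccc(Cl)cc4F)C3)n2)CC1`, is measured in an ADME assay on the whole organism (Mus musculus, strain ICR) for metabolic stability, read by LC-MS, with a stated time of 24 h, at a dose of 2 mg/kg by the intravenous route (a lower number here means that the compound disappears faster, a higher number that the compound lasts longer), and gives 5 h. Compound 1, `CCN1CCN(c2cc(Nc3cc(C)nn3C(=O)C(C)(C)C)nc(N[C@H]3CCN(C(=O)c4ccc(Cl)cc4F)C3)n2)CC1`, gives 5.5 h in this assay, and the two numbers lie within the usual scatter of each other, so neither can be called the longer-lasting of the pair.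

Compound 3, `CCOC(=O)n1nc(C)cc1Nc1cc(N2CCN(CC)CC2)nc(N[C@H]2CCN(C(=O)c3ccc(Cl)cc3F)C2)n1`, has not yet been measured. It differs from compound 2 in one place: ethyl in place of tert-butyl on an oxygen next to a carbonyl group.

Among the compounds with values here, the only measured step, a 1.1-fold lower number from compound 1 to compound 2 (0.04 log units; within the scatter), concerns the same carbonyl-bearing group and produced no change beyond the scatter. Within the data shown here, there is no measured pair that exchanges tert-butyl for ethyl on an oxygen, so the expectation rests on that single step. From compound 2 to compound 3 the expected step is a 1.1-fold lower number from compound 2 to compound 3 (0.05 log units; within the scatter), with no direction claimed beyond the scatter. Compound 3 is therefore estimated at 4.5 h in this assay, with a range from 2.5 h to 9 h.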

Compound 3, half-life: 5.8 h
Compound 3: the middle estimate sits 1.3-fold (0.11 log units) below what was measured; the measured number falls inside the stated range.
By their numbers in this assay, from the lowest: compounds 2, 1 and 3 (each within the scatter of the next).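

In this assay the exchange of tert-butyl for ethyl on an oxygen next to a carbonyl group gives a 1.2-fold higher number from compound 2 to compound 3 (0.06 log units; within the scatter) and so leaves the half-life unresolved from that of compound 2. Compound 3 also stands against compound 1, where ethoxy in place of tert-butyl on a carbonyl carbon gives a 1.1-fold higher number from compound 1 to compound 3 (0.02 log units; within the scatter) as a second step too small to read. Among these three compounds, then, tert-butyl, tert-butoxy and ethoxy on this carbonyl carbon cannot be told apart in this read-out, and no measured evidence offers an explanation for that.

Going by these compounds, whether this position is tolerant in general remains open, since all three groups are close relatives. An amine or a longer chain such as n-hexyloxy on the same carbonyl carbon could behave differently.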